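Fused bicyclic series: aryl swap and cytotoxicity

This account rests on a few compounds, and the source may have more. Where it says the series, first, only, none or still open, it means among the compounds named here.

Measured so far:
compound 1 `O=C1CCCC2=C1C(c1ccc(F)cc1Cl)N=C(c1ccccn1)N2` gives 620000 nM
compound 2 `O=C1CCCC2=C1C(c1ccc(F)cc1Cl)N=C(c1ccco1)N2` gives 717000 nM
compound 3 `O=C1CCCC2=C1C(c1ccc(F)cc1Cl)N=C(c1ccncc1)N2` gives 142000 nM

The three measured compounds share one core and differ only in the group on the carbon with a double bond to nitrogen, between two ring nitrogen atoms. In an ADME assay on HepG2 2.2.15 cells (Homo sapiens) for cytotoxicity (a higher number here means a weaker inhibitor, a lower number a stronger inhibitor), compound 3 holds the lowest number of the three, and both of its steps to the others are beyond the scatter: a 4.4-fold lower number from compound 1 to compound 3 (0.64 log units; beyond the scatter) and a 5.0-fold lower number from compound 2 to compound 3 (0.70 log units; beyond the scatter). Compound 1 and compound 2, by contrast, lie within the scatter of each other: a 1.2-fold higher number from compound 1 to compound 2 (0.06 log units; within the scatter).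

Compound 4 `O=C1CCCC2=C1C(c1ccc(F)cc1Cl)N=C(c1c(F)cc(F)cc1F)N2` has not yet been measured in this assay. Its difference from compound 3: 2,4,6-trifluorophenyl in place of pyridin-4-yl on a carbon with a double bond to nitrogen

Going by the values given here, no measured step exchanges a pyridin-4-yl for a ring of carbon only, so the steps that bear on this change are the two that lead into compound 3 from compound 1 and compound 2. Both were modest and both ran downward toward compound 3, so undoing the pyridin-4-yl is expected to move the number back upward by a comparable modest amount, with wide uncertainty about where a trifluorophenyl sits in this assay. The step expected from compound 3 to compound 4 in this assay is a 3.2-fold higher number from compound 3 to compound 4 (0.50 log units; beyond the scatter). Compound 4 is therefore estimated at 450000 nM, within a range from 150000 nM to 1000000 nM.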

Compound 4, half-maximal inhibitory concentration: 123000 nM
For compound 4 the middle estimate is 3.7-fold (0.56 log units) above the measured one; the measured number lies below the stated range.
By their numbers in this assay, from the lowest: compounds 4 and 3 (each within the scatter of the next); then compounds 1 and 2 (each within the scatter of the next).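

In this assay the change from pyridin-4-yl to 2,4,6-trifluorophenyl gives a 1.2-fold lower number from compound 3 to compound 4 (0.06 log units; within the scatter) and so leaves compound 4 level with compound 3: a ring nitrogen is not required at this position for a number at the low end of the series, since a ring of carbon only, with no hydrogen-bond acceptor, serves equally. The other two steps, a 5.8-fold lower number from compound 2 to compound 4 (0.77 log units; beyond the scatter) and a 5.0-fold lower number from compound 1 to compound 4 (0.70 log units; beyond the scatter), place furan-2-yl and pyridin-2-yl together at the high end. Pyridin-2-yl and pyridin-4-yl fall on opposite sides. The mere presence of a ring nitrogen does not sort the series into its two levels. Nothing at hand accounts for this split between the two levels.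

Still open, as far as these compounds go, is how much of the result for compound 4 belongs to the fluorines, as a plain phenyl or a phenyl with a single fluorine would be needed to separate them from the carbon-only ring itself. Equally open, from the compounds shown here alone, is how this position responds to groups of a different kind, such as an amine, a carboxylic acid or a longer alkyl chain, in place of an aromatic ring.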